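The source may report more compounds than this note shows. Statements on the series, on what has been measured and on what is new or still open speak of the compounds shown alone.

In a functional assay on WiDr cells (Homo sapiens) for antiproliferative activity, read by sulforhodamine B assay, with a stated time of 48 h (a lower number here means a stronger inhibitor of growth, a higher number a weaker inhibitor of growth), compound 1 (`COC(=O)/C=C\[C@H]1OCCC[C@H]1O[Si](C)(C)C(C)(C)C`) gives 38000 nM. Compound 2 (`COC(=O)/C=C/[C@H]1OCCC[C@H]1O[Si](C)(C)C(C)(C)C`) is recorded as > 100000 nM, and this is a limit of the assay, not a measured number. Compound 2 therefore sits at the weak end of the two results so far, with no exact value to start from.

Compound 3 (`COC(=O)/C=C/[C@H]1OCCC[C@@H]1O[Si](C)(C)C(C)(C)C`) keeps the same atoms and bonds as compound 2, and the change is purely one of spatial arrangement: the two compounds have the same atoms and bonds and differ only in configuration as drawn: 1 of 3 stereo elements differ; a stereocentre at a saturated ring carbon is drawn R in compound 2 and S in compound 3. For the measured compounds named here, only one measured step bears on this, an at least 2.6-fold higher number from compound 1 to compound 2 (0.42 log units; beyond the scatter). That step, at a double bond drawn Z and then E, lies beyond the scatter and shows that configuration alone can move the result in this series. However, it concerns a different stereo element, so it gives the likely size of a change here only loosely, and it says nothing firm about direction.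

Since compound 2 has no exact value, any visible change would have to be toward a lower number, and a modest one is expected. The expected change is an at least 1.4-fold lower number from compound 2 to compound 3 (0.15 log units; that floor lies within the scatter). For compound 3 the estimated value is 70000 nM, with an expected range from 25000 nM to 200000 nM.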

Compound 3, concentration for 50% growth inhibition: 84000 nM
For compound 3 the middle estimate is 1.2-fold (0.08 log units) below the measured one; low and high end bracket the measured number.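

Compound 2 is recorded at > 100000 nM, which is a limit of the assay and not a number. Against that limit, turning the saturated ring carbon from R to S gives an at least 1.1-fold lower number from compound 2 to compound 3 (0.07 log units; that floor lies within the scatter), so this single stereocentre has no effect that can be told apart from the scatter, and its true size stays unknown. The new information is an exact number for a compound with an E double bond, which gives a 2.2-fold higher number from compound 1 to compound 3 (0.34 log units; beyond the scatter), a step that changes both the double bond and the ring stereocentre, so it cannot be credited to either one alone, although the gap comes from configuration only: the fact that compounds 1 and 3 differ only in the configuration as drawn

On these data alone, what the ring stereocentre does when the double bond is drawn Z remains open. As far as these compounds go, it is also open whether a free hydroxyl in place of the tert-butyldimethylsilyl ether, or a carboxylic acid in place of the methyl ester, would move the number in this assay further than any change of configuration seen here.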